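The source may report more compounds than this note shows. Statements on the series, on what has been measured and on what is new or still open speak of the compounds shown alone.

Compound 3 `CCN1CCN(CCCOc2cc3nccc(Oc4c(F)cc(NC(=O)NN5C(=O)CSC5c5c(F)cccc5F)cc4F)c3cc2OC)CC1` is the stronger of the two measured analogues: in a functional assay on MDA-MB-231 cells (Homo sapiens) for antiproliferative activity, read by MTT assay, with a stated time of 72 h (on this read-out lower numbers stand for stronger inhibition and higher numbers for weaker inhibition), compound 3 gives 3100 nM, while compound 2 `COc1cc2c(Oc3c(F)cc(NC(=S)NN4C(=O)CSC4c4c(F)cccc4F)cc3F)ccnc2cc1OCCCN1CCCC1` gives 8120 nM, a gap beyond the usual scatter. Compound 1 `COc1cc2c(Oc3ccc(NC(=O)NN4C(=O)CSC4c4c(F)cccc4F)c(Cl)c3)ccnc2cc1OCCCN1CCCC1` has no result reported: in this assay compound 1 gives "not determined" (no result reported). Compound 4 `COc1cc2c(Oc3c(F)cc(NC(=O)NN4C(=O)CSC4c4c(F)cccc4F)cc3F)ccnc2cc1OCCCN1CCC(C)CC1` differs from compound 3 in one place: 4-methylpiperidin-1-yl in place of 4-ethylpiperazin-1-yl on a saturated chain carbon, three bonds along the chain from an oxygen on an aromatic ring. Going by the values given here, no pair of measured compounds shows this change, so its effect is unknown here. The expectation is a step from compound 3 to compound 4 of a 1.0-fold lower number from compound 3 to compound 4 (0.01 log units; within the scatter), not beyond the scatter in either direction. Compound 4 is therefore expected at 3000 nM, with a range from 1000 nM to 9000 nM.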

Compound 4, half-maximal inhibitory concentration: 3830 nM
Compound 4: the middle estimate sits 1.3-fold (0.11 log units) below what was measured; measured number inside the range.
By their numbers in this assay, from the lowest: compounds 3 and 4 (each within the scatter of the next); then compound 2.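

In this assay the exchange of 4-ethylpiperazin-1-yl for 4-methylpiperidin-1-yl on this saturated chain carbon gives a 1.2-fold higher number from compound 3 to compound 4 (0.09 log units; within the scatter) and so no real change. At this position, then, a ring with 2 hetero atoms and a ring with 1 hetero atom cannot be told apart in this assay. No measurement shown offers a reason for this result.

Still open, on these data alone, is whether a morpholine ring or an open-chain dimethylamino group at the end of this propyl chain would also leave the number unchanged. A longer chain carrying either ring also remains untested among the compounds shown.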